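The source may report more compounds than this note shows. Statements on the series, on what has been measured and on what is new or still open speak of the compounds shown alone.

Measured so far in a functional assay on a cell-free system (plasma, Oryctolagus cuniculus) for inhibition, with stated times of 5 min, 1 min and 6 min; a higher number here means a weaker inhibitor, a lower number a stronger inhibitor:

Compound 1, `CCOC(=O)c1c(C)nc(-c2cccc(C#N)c2)n1C`: compound 1 gives 22100 nM.
Compound 2, `CCOC(=O)c1c(C)nc(-c2cccc(C#N)c2)n1C(C)C`: compound 2 gives 9260 nM.
Compound 3, `CCOC(=O)c1c(C)nc(-c2cccc(C#N)c2)n1OCc1ccccc1F`: compound 3 gives 8990 nM.

Compound 3 carries the lowest number of the three, but its separation from compound 2 is within the scatter (a 1.0-fold lower number from compound 2 to compound 3 (0.01 log units; within the scatter)), so the two cannot be ranked; only against compound 1 is compound 3 set apart (a 2.5-fold lower number from compound 1 to compound 3 (0.39 log units; beyond the scatter)), much as compound 2 is (a 2.4-fold lower number from compound 1 to compound 2 (0.38 log units; beyond the scatter)).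

Compound 4, `CCOC(=O)c1c(C)nc(-c2cccc(C#N)c2)n1OCc1ccc(C#N)cc1`, differs from compound 3 in one place: 4-cyanophenyl in place of 2-fluorophenyl on a saturated chain carbon bound to an oxygen on an aromatic ring. None of the three measured steps touches this part of the molecule; all three vary the group on the aromatic nitrogen while the 2-fluorobenzyl group, where present, is kept. Within the data shown here, there is therefore no measured step that bears on the change from compound 3 to compound 4, and no step beyond the scatter is expected in this assay in either direction.

Compound 4 is expected to give about 9000 nM in this assay, with a range from 3000 nM to 27000 nM, the step from compound 3 being estimated as a 1.0-fold higher number from compound 3 to compound 4 (0.00 log units; within the scatter).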

Compound 4, half-maximal inhibitory concentration: 4240 nM
Estimate against measurement, compound 4: 2.1-fold (0.33 log units) above, within the range that was stated.
By their numbers in this assay, from the lowest: compound 4; then compounds 3 and 2 (each within the scatter of the next); then compound 1.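

The group beyond the oxygen on the aromatic nitrogen still responds in this assay: replacing 2-fluorobenzyl with 4-cyanobenzyl gives a 2.1-fold lower number from compound 3 to compound 4 (0.33 log units; beyond the scatter), a modest step but one beyond the scatter. Among these compounds, the earlier steps varied only the group on the aromatic nitrogen, so this is the first sign that the aryl ring of the benzyl group can itself shift the number while the rest of compound 3 stays fixed. No measurement at hand accounts for this step.

Fluorine leaves and a nitrile enters in the same change, so the share of each remains open, and a plain phenyl would be needed to separate them. On these data alone, how a carboxylic acid or an amine in place of that nitrile would read in this assay also remains open.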